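This account rests on a few compounds, and the source may have more. Where it says the series, first, only, none or still open, it means among the compounds named here.

In a functional assay on U-373MG ATCC cells (Homo sapiens) for inhibition, read by colorimetric assay and MTT assay, with a stated time of 72 h (on this read-out lower numbers stand for stronger inhibition and higher numbers for weaker inhibition), compound 1 `C=CCCCCOc1ccccc1-c1cnc(OCCCCC=C)n1C` gives 7000 nM. Compound 2 `Cn1c(-c2ccccc2O)cnc1S(=O)(=O)c1ccccc1` gives > 100000 nM, which is a limit of the assay and not a number. Compound 2 therefore has no exact position in this series, only (the limit of > 100000 nM in this assay, at which 1 of the 2 values shown sits).

Compound 3 `C=CCCCCOc1ccccc1-c1cnc(S(=O)(=O)c2ccccc2)n1C` follows from compound 2 by one change: hex-5-en-1-yl in place of hydrogen on an oxygen on an aromatic ring. In words, hex-5-en-1-yl stands in place of hydrogen on an oxygen on an aromatic ring, turning hydroxy into (hex-5-en-1-yl)oxy. For the measured compounds named here, no measured single-change step is available to calibrate this change in this assay. A lower number is expected, resting on compound 1, which also carries (hex-5-en-1-yl)oxy and gives 7000 nM. The expected step, an at least 5.0-fold lower number from compound 2 to compound 3 (0.69 log units; beyond the scatter), is towards stronger inhibition and moderate in size. Compound 3 is estimated at 20000 nM, with an expected range of 6000 nM to 80000 nM.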

Compound 3, half-maximal inhibitory concentration: 63000 nM
For compound 3 the middle estimate is 3.2-fold (0.50 log units) below the measured one, and the stated range covers the measured number.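

In this assay, an at least 1.5-fold lower number from compound 2 to compound 3 (0.20 log units; that floor lies within the scatter) for hex-5-en-1-yl in place of hydrogen on an oxygen on an aromatic ring, so this change is known only as a floor and that floor stays within the scatter. Compound 2 stands at a limit of the assay, not at a number: the limit of > 100000 nM in this assay, at which 1 of the 3 values shown sits. The clearer reading comes from the aromatic carbon, where a 9.0-fold higher number from compound 1 to compound 3 (0.95 log units; beyond the scatter) for phenylsulfonyl in place of (hex-5-en-1-yl)oxy, a move towards weaker inhibition with (hex-5-en-1-yl)oxy kept on the other site.

Going by these compounds, the true size of the hydroxy to (hex-5-en-1-yl)oxy change remains open while compound 2 has only a limit. Also open, on these data alone, is how a shorter chain on that oxygen, or an amine on the aromatic carbon, would read in this assay against these compounds.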